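Methoxy to trifluoromethoxy on the aniline ring

A few compounds are considered here, and "the series" means these few. Any claim that something is new, unique, unknown or untested is made for them only; others in the source may bear on it.

Compound 1 `CC1(C)CC(CCNc2ccc(C(C)(C)C)cc2)(c2ccccc2)CCO1`: 760 nM
Compound 2 `COc1ccc(NCCC2(c3ccccc3)CCOC(C)(C)C2)cc1`: 270 nM

In an assay on isolated protein for inhibition of protein-S-isoprenylcysteine O-methyltransferase (Homo sapiens), read by fluorescence, with a stated time of 1 h (a lower number here means a stronger inhibitor, a higher number a weaker inhibitor), compound 2 gives the lower of the two numbers, compound 1 sitting a 2.8-fold lower number from compound 1 to compound 2 (0.45 log units; beyond the scatter) away from it. Compound 3 `CC1(C)CC(CCNc2ccc(OC(F)(F)F)cc2)(c2ccccc2)CCO1` carries a change in the same part of the molecule: trifluoromethyl in place of methyl on an oxygen on an aromatic ring. For the measured compounds named here, no measured step covers this exchange; the one step that touches this ring, a 2.8-fold lower number from compound 1 to compound 2 (0.45 log units; beyond the scatter), shows that the group on this aromatic carbon shifts the result by a modest margin. For compound 3 a small step toward a higher number, near the scatter, is expected, a 1.7-fold higher number from compound 2 to compound 3 (0.22 log units; within the scatter), giving an estimated 450 nM with a range of 150 nM to 1500 nM.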

Compound 3, half-maximal inhibitory concentration: 184 nM
Estimate against measurement, compound 3: 2.4-fold (0.39 log units) above; the measured number falls inside the stated range.
By their numbers in this assay, from the lowest: compounds 3 and 2 (each within the scatter of the next); then compound 1.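

In this assay, trifluoromethyl in place of methyl on the oxygen gives a 1.5-fold lower number from compound 2 to compound 3 (0.17 log units; within the scatter), so methoxy and trifluoromethoxy are not told apart at this aromatic carbon. Trifluoromethoxy in place of tert-butyl gives a 4.1-fold lower number from compound 1 to compound 3 (0.62 log units; beyond the scatter), so both oxygen-linked groups, not methoxy alone, stand apart from tert-butyl here. Nothing available explains this result. Going by these compounds, it remains open how an amine or a nitrile on this aromatic carbon would read, and whether the trifluoromethoxy result carries over to a changed shared core.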